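The source may hold more compounds than are shown below. What is called first, only, known or untested is meant among the compounds shown, and "the series" means these compounds.

Compound 3 `CCOc1ccc(NC(=O)c2ccc(C(CC)(CC)c3ccc(OCCC(O)(CC)CC)c(C)c3)n2CC)cc1` carries (4-ethoxyphenyl)amino on the carbonyl carbon of the shared core. In a functional assay on HepG2 cells (Homo sapiens) for antiproliferative activity, read by MTT assay, with a stated time of 48 h (on this read-out lower numbers stand for stronger inhibition and higher numbers for weaker inhibition), compound 3 returns only a limit of the assay, > 50000 nM. Compound 2 `CCn1c(C(=O)Nc2cccc(C(F)(F)F)c2)ccc1C(CC)(CC)c1ccc(OCCC(O)(CC)CC)c(C)c1` likewise returns a limit in this assay, > 50000 nM. Going by the values given here, compound 1 `CCn1c(C(=O)N(CCC#N)CCC#N)ccc1C(CC)(CC)c1ccc(OCCC(O)(CC)CC)c(C)c1` is the only member with a number and gives 46300 nM in this assay. Two of the three values thus sit at the limit of > 50000 nM in this assay, at which 2 of the 3 values shown sit, so the steps of an at least 1.0-fold higher number from compound 1 to compound 2 (0.03 log units; that floor lies within the scatter) and an at least 1.0-fold higher number from compound 1 to compound 3 (0.03 log units; that floor lies within the scatter) have only floors within the scatter, and the step that the two limits leave unreadable from compound 2 to compound 3 cannot be read at all.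

Compound 4 `CCn1c(C(=O)N(C)CCO)ccc1C(CC)(CC)c1ccc(OCCC(O)(CC)CC)c(C)c1` differs from compound 3 by (2-hydroxyethyl)(methyl)amino in place of (4-ethoxyphenyl)amino on a carbonyl carbon. Among the compounds with values here, the amide nitrogen again carries no ring, as in compound 1, and the one step that bears on this, an at least 1.0-fold higher number from compound 1 to compound 3 (0.03 log units; that floor lies within the scatter), shows no readable movement. Within the data shown here, no measured step leaves the scatter, so no shift beyond it is expected, and the step of an at least 1.1-fold lower number from compound 3 to compound 4 (0.04 log units; that floor lies within the scatter) is estimated to stay within it. Compound 4 is expected to give 45000 nM in this assay, with a range from 12000 nM to 100000 nM.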

Compound 4, half-maximal inhibitory concentration: 510 nM
Compound 4: the middle estimate sits 88-fold (1.95 log units) above what was measured; measured number below the stated range.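

Going by these compounds alone, on the carbonyl carbon of the shared core, the attached group can move the read-out in this assay well beyond the scatter, which no step among the earlier compounds showed: (2-hydroxyethyl)(methyl)amino in place of (4-ethoxyphenyl)amino gives an at least 98-fold lower number from compound 3 to compound 4 (1.99 log units; beyond the scatter). The same group in place of (3-(trifluoromethyl)phenyl)amino gives an at least 98-fold lower number from compound 2 to compound 4 (1.99 log units; beyond the scatter), and both of these sizes are floors only: the limit of > 50000 nM in this assay, at which 2 of the 4 values shown sit. The absence of a ring does not by itself go with the large step, as the ring-free group of 9 heavy atoms, replaced by the ring-free (2-hydroxyethyl)(methyl)amino, gives a 91-fold lower number from compound 1 to compound 4 (1.96 log units; beyond the scatter).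

Which part of (2-hydroxyethyl)(methyl)amino goes with this step remains open. A 2-methoxyethyl group, a longer hydroxyalkyl chain or a terminal amine in its place would help separate the hydroxyl, the chain length and the methyl on nitrogen.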